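This account rests on a few compounds, and the source may have more. Where it says the series, first, only, none or still open, it means among the compounds named here.

Compound 1 `NC(=O)[C@H](CO)Nc1cc(=O)oc2cc(OCc3cccc(Cl)c3)ccc12` is the starting point of these notes. In an assay (strain Wistar) for inhibition of Amine oxidase [flavin-containing] A (Rattus norvegicus) (on this read-out lower numbers stand for stronger inhibition and higher numbers for weaker inhibition), compound 1 gives > 100000 nM, which is a limit of the assay and not a number, so compound 1 stands at the limit of > 100000 nM in this assay, at which 1 of the 2 values shown sits. Compound 2 `CN(C)C(=O)Cc1cc(=O)oc2cc(OCc3ccccc3)ccc12` carries a different substituent pattern, and in this assay compound 2 gives 23100 nM. Compound 3 `CN(Cc1ccccc1)Cc1cc(=O)oc2cc(OCc3cccc(Cl)c3)ccc12` is still to be measured; it differs from compound 1 by (benzyl(methyl)amino)methyl in place of (1-carbamoyl-2-hydroxyethyl)amino on an aromatic carbon, in words (benzyl(methyl)amino)methyl in place of (1-carbamoyl-2-hydroxyethyl)amino on an aromatic carbon. Among the compounds with values here, with no step between measured compounds known, the step of an at least 20-fold lower number from compound 1 to compound 3 (1.30 log units; beyond the scatter) is expected to run towards stronger inhibition, beyond the scatter. Compound 3 is expected to give 5000 nM in this assay, within 500 nM to 50000 nM.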

Compound 3, half-maximal inhibitory concentration: > 100000 nM
Compound 3 ended at the assay's limit; the forecaster's own chance of this, stated with the estimate: 15%; at least 20-fold (1.30 log units) between middle value and limit.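

Within the data shown here, compound 1 and compound 3 both end at a limit of this assay and not at a number, so no step between them can be read: the limit of > 100000 nM in this assay, at which 2 of the 3 values shown sit.

The compounds shown leave open whether any group on this aromatic carbon brings the core of compound 1 clear of that limit.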